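The source may report more compounds than this note shows. Statements on the series, on what has been measured and on what is new or still open speak of the compounds shown alone.

Measured so far, all in one assay:

Compound 1 `CCN(CC)c1ccc2cc(C(=O)c3ccc(N4CCN(C(=O)CN5CCN(C(=O)CCl)CC5)CC4)cc3)oc2c1` — in an ADME assay on L02 cells (Homo sapiens) for cytotoxicity, read by MTT assay, with a stated time of 48 h (on this read-out lower numbers stand for stronger inhibition and higher numbers for weaker inhibition), compound 1 gives 20900 nM.
Compound 2 `CCN(CC)c1ccc2cc(C(=O)c3ccc(N4CCN(C(=O)CN5CCN(S(=O)(=O)c6ccc(C#N)cc6)CC5)CC4)cc3)oc2c1` — in this assay compound 2 gives 44100 nM.
Compound 3 `C#CCN1CCN(CC(=O)N2CCN(c3ccc(C(=O)c4cc5ccc(N(CC)CC)cc5o4)cc3)CC2)CC1` — in this assay compound 3 reaches only the assay limit, > 100000 nM.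

Compound 3 therefore sits at the upper edge of what the assay reports (the limit of > 100000 nM in this assay, at which 1 of the 3 values shown sits); it gives the highest number of the three, with an at least 4.7-fold higher number from compound 1 to compound 3 (0.67 log units; beyond the scatter) and an at least 2.2-fold higher number from compound 2 to compound 3 (0.35 log units; beyond the scatter), both beyond the scatter. The third measured step, a 2.1-fold higher number from compound 1 to compound 2 (0.32 log units; beyond the scatter), is also modest. All three steps exchange the group on the same amine nitrogen in a ring, and each exchange moved the number by no more than a modest amount.

Compound 4 `CCOC(=O)CN1CCN(CC(=O)N2CCN(c3ccc(C(=O)c4cc5ccc(N(CC)CC)cc5o4)cc3)CC2)CC1` differs from compound 3 by ethoxycarbonyl in place of ethynyl on a saturated chain carbon bound to an amine nitrogen in a ring. Within the data shown here, none of the measured steps swaps ethynyl for ethoxycarbonyl; the nearest evidence is that every change on this part of the molecule has shifted this assay only modestly. For compound 4 a step of about an at least 1.1-fold lower number from compound 3 to compound 4 (0.04 log units; that floor lies within the scatter) is expected, that is, no movement beyond the scatter. Compound 4 is thus estimated to give about 90000 nM in this assay, with a plausible range from 30000 nM to 300000 nM, and a fair chance that only a limit is reported.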

Compound 4, half-maximal inhibitory concentration: 68700 nM
Beside the measured number, compound 4's estimate is 1.3-fold (0.12 log units) above it; the range from low to high includes it.
By their numbers in this assay, from the lowest: compound 1; then compounds 2 and 4 (each within the scatter of the next). At a limit, above all of these: compound 3.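

In this assay the exchange of ethynyl for ethoxycarbonyl on a saturated chain carbon bound to an amine nitrogen in a ring gives an at least 1.4-fold lower number from compound 3 to compound 4 (0.16 log units; that floor lies within the scatter), which is a floor only, since one end of the step is a limit: the limit of > 100000 nM in this assay, at which 1 of the 4 values shown sits. The ester-bearing group also gives a number that cannot be told apart from the sulfonyl one, with a 1.6-fold higher number from compound 2 to compound 4 (0.19 log units; within the scatter), so (ethoxycarbonyl)methyl and (4-cyanophenyl)sulfonyl on this nitrogen are not separated by this read-out. (Chloromethyl)carbonyl remains the group set apart from the others, with a 3.3-fold higher number from compound 1 to compound 4 (0.52 log units; beyond the scatter), and in all three of its steps compound 1 has the lowest number, though each step is modest or, where the other end is a limit, at least modest.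

The compounds shown leave open whether the number follows ethoxycarbonyl itself or only the saturated chain carbon that carries it, which a carboxylic acid or a primary amide in its place would test. They also leave open whether a free amine on this nitrogen would move the number further than the steps seen so far.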